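This account rests on a few compounds, and the source may have more. Where it says the series, first, only, none or still open, it means among the compounds named here.

In a functional assay on SF-295 cells (Homo sapiens) for antiproliferative activity (on this read-out lower numbers stand for stronger inhibition of growth and higher numbers for weaker inhibition of growth), compound 1 `Cc1ccc2c(O)cc(-c3cccc(Cl)c3)nc2n1` gives 22.9 nM and compound 2 `Cc1ccnc2nc(-c3cccc4ccccc34)cc(O)c12` gives 10.7 nM as the lower of the two numbers, a gap beyond the usual scatter. Compound 3 `Cc1cc(C)c2c(O)cc(-c3cccc4ccccc34)nc2n1` differs from compound 2 by methyl in place of hydrogen on an aromatic carbon. For the measured compounds named here, no measured pair shows this change, so the expectation rests on the small size of the change alone, with no shift beyond the scatter expected. The estimated move is a 1.4-fold higher number from compound 2 to compound 3 (0.15 log units; within the scatter) in this assay at most a slight weakening. For compound 3 the expected value is 15 nM with an estimated range of 5 nM to 50 nM on this read-out.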

Compound 3, concentration for 50% growth inhibition: 589 nM
The estimate for compound 3 lay 39-fold (1.59 log units) below the measured number; the whole stated range lies below it.
By their numbers in this assay, from the lowest: compound 2; then compound 1; then compound 3.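

Methyl in place of hydrogen on an aromatic carbon, next to the ring nitrogen, gives a 55-fold higher number from compound 2 to compound 3 (1.74 log units; beyond the scatter) in this assay. For the compounds shown here, this is the first step read, and it shows that this position is highly sensitive, since a single added heavy atom costs most of the activity of compound 2. No measurement at hand accounts for this loss. Still open, from the compounds shown here alone, is whether the loss is specific to methyl or arises with any group at this carbon. Fluorine, methoxy or an amine there would separate the two cases.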